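Sulfur for oxygen in the fused bicyclic ether of compound 2

The source may hold more compounds than are shown below. What is called first, only, known or untested is meant among the compounds shown, and "the series" means these compounds.

Compound 2 `FC(F)(F)c1cc(Oc2nccc3occc23)ccc1-c1cccc2nccn12` holds the lower of the two numbers measured: in an assay on cells for displacement of a labelled ligand from 5-hydroxytryptamine receptor 5A (Homo sapiens), read by scintillation counting, with a stated time of 90 min (a higher number here means a weaker inhibitor, a lower number a stronger inhibitor), compound 2 gives 7400 nM, while compound 1 `Cc1ncc2nccn2c1-c1ccc(Oc2nccc3occc23)cc1C(F)(F)F` gives 9500 nM. The step of a 1.3-fold lower number from compound 1 to compound 2 (0.11 log units; within the scatter) lies within the scatter. Compound 3 `FC(F)(F)c1cc(Oc2nccc3ccsc23)ccc1-c1cccc2nccn12` differs from compound 2 by a group of 9 heavy atoms (7 carbon, 1 nitrogen, 1 sulfur; one five-membered aromatic ring with 1 hetero atom, one six-membered aromatic ring with 1 hetero atom) in place of a group of 9 heavy atoms (7 carbon, 1 nitrogen, 1 oxygen; one five-membered aromatic ring with 1 hetero atom, one six-membered aromatic ring with 1 hetero atom), on an oxygen on an aromatic ring. Within the data shown here, that single measured step concerns a different part of the shared core, so no measured step bears directly on this change. One therefore expects the step of a 1.1-fold lower number from compound 2 to compound 3 (0.06 log units; within the scatter) to stay within the scatter. For compound 3 the estimate in this assay is 6500 nM, with a range from 2500 nM to 17000 nM.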

Compound 3, inhibition constant: 6200 nM
Estimate against measurement, compound 3: 1.0-fold (0.02 log units) above; measured number inside the range.
By their numbers in this assay, from the lowest: compounds 3, 2 and 1 (each within the scatter of the next).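

In this assay, the group with sulfur in place of the group with oxygen, on an oxygen on an aromatic ring, gives a 1.2-fold lower number from compound 2 to compound 3 (0.08 log units; within the scatter). This position had not varied in compounds 1 and 2, and this one exchange leaves the number within the scatter. Nothing shown gives a reason for this result.

As far as these compounds go, whether an amine or a carboxylic acid on the group at this position would move the number beyond the scatter stays open. So does whether the same exchange would give a similar step on the core of compound 1.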